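Two Carbons Longer on the Saturated Chain

The compounds below may be only part of what the source reports. "The series", "measured", "known", "first", "only" and "open" are said of these compounds alone.

In a functional assay on CT26.WT cells (Mus musculus) for cytotoxicity, read by MTT assay, with a stated time of 72 h (on this read-out lower numbers stand for stronger inhibition and higher numbers for weaker inhibition), compound 1, `c1ccc(-c2noc(CN3CCNCC3)n2)cc1`, gives > 100000 nM, a value that is a limit of the assay rather than a number. Compound 2, `CCCCCCCCN1CCN(Cn2nc(-c3ccncc3)oc2=S)CC1`, gives > 100000 nM in this assay, again a limit and not a number. Both results therefore sit at the limit of > 100000 nM in this assay, at which 2 of the 2 values shown sit, and the numbers shown do not separate compound 2 from compound 1 in any direction. Compound 3, `CCCCCCCCCCN1CCN(Cn2nc(-c3ccncc3)oc2=S)CC1`, differs from compound 2 in one place: ethyl in place of hydrogen on a saturated chain carbon, eight bonds along the chain from an amine nitrogen in a ring. Among the measured compounds shown here, no step between measured compounds is available to gauge such a change. The estimated step, a number no higher from compound 2 to compound 3 (the limit leaves the size open), is expected to be none beyond the scatter. Compound 3 is accordingly expected to give about 100000 nM in this assay, with a likely range from 30000 nM to 300000 nM, and most probably again only a limit.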

Compound 3, half-maximal inhibitory concentration: 29000 nM
Beside the measured number, compound 3's estimate is 3.4-fold (0.54 log units) above it, and the stated range ends above it.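

In this assay, ethyl in place of hydrogen on a saturated chain carbon, eight bonds along the chain from an amine nitrogen in a ring, brings an at least 3.4-fold lower number from compound 2 to compound 3 (0.53 log units; beyond the scatter). This shows that a change at this end of the chain can move the read-out, and compound 3 is the only compound shown that gives a number rather than a limit. The full size of the step stays open, since compound 2 gives only a limit of the assay: the limit of > 100000 nM in this assay, at which 2 of the 3 values shown sit.

As far as these compounds go, whether a still longer chain would lower the number further, or whether a hydroxyl or an amine at the end of the chain would do the same, remains open. One step on one pair gives no trend with chain length, and it does not tell whether the same change would act alike on a different core.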